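Chloro for fluoro on the benzyl arm: the next compound

The source may hold more compounds than are shown below. What is called first, only, known or untested is meant among the compounds shown, and "the series" means these compounds.

Measured so far in an ADME assay on HEK-293T cells (Homo sapiens) for antiproliferative activity, read by MTT assay, with a stated time of 48 h, in the presence of a further agent that is not named here; on this read-out lower numbers stand for higher toxicity in this test and higher numbers for lower toxicity in this test:
compound 1 `Cc1ccc(-c2nn(-c3ccccc3)cc2C(=O)NOCc2ccccc2F)cc1` gives 20600 nM
compound 2 `Cc1ccc(-c2nn(-c3ccccc3)cc2C(=O)NOCc2ccccc2Cl)cc1` gives 38700 nM
compound 3 `O=C(NOCc1ccccc1F)c1cn(-c2ccccc2)nc1-c1ccc(Cl)cc1` gives 126000 nM

All three share one core apart from a single group. The core of compound 3 differs from that of compound 1 by chloro in place of methyl on an aromatic carbon, and this change made a step of a 6.1-fold higher number from compound 1 to compound 3 (0.79 log units; beyond the scatter). Compound 3 therefore stands at the highest number of the three, with its steps to compound 2 and to compound 1 both beyond the usual scatter.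

The change from compound 1 to compound 2 is chloro in place of fluoro on an aromatic carbon. It made a step of a 1.9-fold higher number from compound 1 to compound 2 (0.27 log units; within the scatter), too small to be told apart from repeat measurement.

Compound 4 `O=C(NOCc1ccccc1Cl)c1cn(-c2ccccc2)nc1-c1ccc(Cl)cc1` has not yet been measured in this assay. It differs from compound 3 by chloro in place of fluoro on an aromatic carbon, the same change as from compound 1 to compound 2, at the same place. Because that change gave a 1.9-fold higher number from compound 1 to compound 2 (0.27 log units; within the scatter), a step of the same small size is expected here, which is estimated as a 1.7-fold higher number from compound 3 to compound 4 (0.22 log units; within the scatter). Compound 4 is thus expected to give about 210000 nM in this assay, most likely between 90000 nM and 480000 nM.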

Compound 4, half-maximal cytotoxic concentration: 129000 nM
For compound 4 the middle estimate is 1.6-fold (0.21 log units) above the measured one, and the stated range covers the measured number.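

In this assay, chloro in place of fluoro on the benzyl arm gave a 1.0-fold higher number from compound 3 to compound 4 (0.01 log units; within the scatter), so on this core too the change cannot be told apart from repeat measurement, and the two cores agree: the same change on two cores in this assay, a 1.9-fold higher number (0.27 log units; within the scatter) from compound 1 to compound 2 and a 1.0-fold higher number (0.01 log units; within the scatter) from compound 3 to compound 4, 1.8-fold (0.26 log units) apart, within the scatter of two such steps

Chloro in place of methyl also carried across, now with the 2-chlorobenzyl arm in place, giving a 3.3-fold higher number from compound 2 to compound 4 (0.52 log units; beyond the scatter), and this step matches the earlier one on the 2-fluorobenzyl arm: the same change on two cores in this assay, a 6.1-fold higher number (0.79 log units; beyond the scatter) from compound 1 to compound 3 and a 3.3-fold higher number (0.52 log units; beyond the scatter) from compound 2 to compound 4, 1.8-fold (0.26 log units) apart, within the scatter of two such steps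

Together these results show that, across these four compounds, each change behaves about the same whichever group sits at the other place, but this rests on only two pairs per change and does not explain why, nor does it show that the same would hold on any other core.

The compounds shown leave open whether the pattern survives with other groups, such as a bromo or a methoxy group in place of the fluoro or chloro on the benzyl arm, or an amine in place of the methyl. They also leave open whether these steps would look the same in a different kind of test.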